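A few compounds are considered here, and "the series" means these few. Any claim that something is new, unique, unknown or untested is made for them only; others in the source may bear on it.

Of the compounds shown here, three sharing one core have been tested in a functional assay on HL-60 cells (Homo sapiens) for inhibition, read by MTT assay, with a stated time of 72 h; on this read-out lower numbers stand for stronger inhibition and higher numbers for weaker inhibition: compound 1 `Cc1nc(-c2ccccc2)c(C(=O)N2CCN(c3cccc(Cl)c3)CC2)o1` gives 39.2 nM, compound 2 `Cc1nc(-c2ccccc2)c(C(=O)N2CCN(c3cccc(Cl)c3Cl)CC2)o1` gives 133 nM and compound 3 `Cc1nc(-c2ccccc2)c(C(=O)N2CCN(c3cccc(C)c3C)CC2)o1` gives 35 nM. Compound 3 stands at the low end of these numbers, but no real gap separates it from its nearest neighbour: the data show a 1.1-fold lower number from compound 1 to compound 3 (0.05 log units; within the scatter). Its furthest neighbour is set apart by a 3.8-fold lower number from compound 2 to compound 3 (0.58 log units; beyond the scatter).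

Compound 4 `Cc1nc(-c2ccccc2)c(C(=O)N2CCN(c3cccc(C(N)=O)c3)CC2)o1` has not yet been measured. It carries 3-carbamoylphenyl in place of 2,3-dimethylphenyl on an amine nitrogen in a ring.

Among the compounds with values here, no measured compound carries a carbamoyl group, so the earlier steps give only a sense of scale. Putting chloro in place of hydrogen on an aromatic carbon produced a 3.4-fold higher number from compound 1 to compound 2 (0.53 log units; beyond the scatter), a modest move, and no change on this aryl group has moved the number further than the modest step already seen for the dichloro compound. A modest rise in this assay therefore seems most likely, since the low end offers little room and a new group is more likely to lose ground than to gain it. The step expected is a 2.6-fold higher number from compound 3 to compound 4 (0.41 log units; beyond the scatter). Compound 4 is estimated at 90 nM, with an expected range from 25 nM to 320 nM.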

Compound 4, half-maximal inhibitory concentration: 71 nM
Compound 4: the middle estimate sits 1.3-fold (0.10 log units) above what was measured, within the range that was stated.
By their numbers in this assay, from the lowest: compounds 3, 1, 4 and 2 (each within the scatter of the next, the first and the last beyond it).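

At this place on the ring amine nitrogen, the aryl group need not be built only from chloro or methyl groups: 3-carbamoylphenyl, which brings a hydrogen-bond donor and acceptor that 2,3-dimethylphenyl lacks, still holds the number in the nanomolar range seen so far, with a modest step (a 2.0-fold higher number from compound 3 to compound 4 (0.31 log units; beyond the scatter)). Carbamoyl in place of chloro (a 1.8-fold higher number from compound 1 to compound 4 (0.26 log units; within the scatter)) and 3-carbamoylphenyl in place of 2,3-dichlorophenyl (a 1.9-fold lower number from compound 2 to compound 4 (0.27 log units; within the scatter)) both stay within the scatter, so this assay does not separate either of these pairs, and a very different group sits among the chloro compounds rather than outside them. Nothing at hand explains why these aryl groups give such close numbers.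

Carbamoyl appears here only as 3-carbamoylphenyl, so a single pair cannot tell whether the amide hydrogens matter, and a carboxylic acid, a nitrile or a methylamide on the same phenyl ring would be needed to test that. How far this tolerance extends also stays open, since the shared core is unchanged throughout and only cell growth read by this one assay is shown.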